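The source may hold more compounds than are shown below. What is called first, only, known or untested is meant among the compounds shown, and "the series" means these compounds.

Compound 1 `FC(F)(F)Oc1ccc(Nc2cc(-c3cn[nH]c3)ncn2)cc1` was examined in an ADME assay on BaF3 cells (Mus musculus) for cytotoxicity (a lower number here means that less compound is needed, a higher number that more compound is needed for the effect), as a measure of cytotoxicity. In this assay compound 1 gives > 10000 nM, which is a limit of the assay rather than a number. Compound 2 `Cc1c(-c2cc(Nc3ccc(OC(F)(F)F)cc3)ncn2)cnn1-c1ccccc1` was also tested, and in this assay compound 2 gives > 10000 nM, again a limit and not a number. Both measured values therefore sit at the same point, described by the limit of > 10000 nM in this assay, at which 2 of the 2 values shown sit, so compound 1 stands at the edge of what the assay reports and nothing distinguishes it from compound 2 on the numbers shown.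

Compound 3 `Nc1cccc(-c2cc(Nc3ccc(OC(F)(F)F)cc3)ncn2)c1` has not yet been measured in this assay. It differs from compound 1 in one place: 3-aminophenyl in place of 1H-pyrazol-4-yl on an aromatic carbon. Among the measured compounds shown here, no step between two measured compounds is available to show how such a change acts in this assay. Given that both measured values lie at the limit, the change from compound 1 to compound 3 is expected to produce no step beyond the scatter, with compound 3 expected to remain at or near the limit.

For compound 3 the expected value in this assay is 15000 nM, within a range from 5000 nM to 50000 nM, corresponding to an expected step that the limit leaves unreadable from compound 1 to compound 3.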

Compound 3, half-maximal effective concentration: > 10000 nM
Compound 3 ended at the assay's limit (the forecaster's own chance of this, stated with the estimate: 75%); the middle value does not contradict the limit.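

Compound 3 also ends at a limit rather than a number, so no step between compound 1 and compound 3 can be read in this assay: the limit of > 10000 nM in this assay, at which 3 of the 3 values shown sit.

The compounds shown leave open whether 3-aminophenyl in place of 1H-pyrazol-4-yl changes cytotoxicity at all, and at what concentration, if any, compound 1, compound 2 or compound 3 would reach the half-maximal effect.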